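Methyl to Ethyl on the Aryl Ring in Two Cores

A few compounds are considered here, and "the series" means these few. Any claim that something is new, unique, unknown or untested is made for them only; others in the source may bear on it.

Measured compounds:
Compound 1 `COC1=C(C)C(=O)/C(=C(O)/C=C/c2ccc(C)cc2)C(=O)C1(C)C`: 1.9 ug/mL
Compound 2 `CCc1ccc(/C=C/C(O)=C2/C(=O)C(C)=C(OC)C(C)(C)C2=O)cc1`: 1.9 ug/mL
Compound 3 `CCC1=C(OC)C(CC)(CC)C(=O)C(C(=O)/C=C/c2ccc(C)cc2)=C1O`: 1 ug/mL

In a functional assay on KB cells (Homo sapiens) for cytotoxicity (a lower number here means that less compound is needed, a higher number that more compound is needed for the effect), compound 1 gives 1.9 ug/mL and compound 2 gives 1.9 ug/mL. Compound 2 differs from compound 1 by methyl in place of hydrogen on a saturated chain carbon bound to an aromatic carbon, and the step in this assay is no change at the digits printed from compound 1 to compound 2 (within the scatter). Compound 3 carries a different core; the difference between the two cores is not broken down here. In this assay compound 3 gives 1 ug/mL, which sits within the scatter of both compound 1 and compound 2, so no order among the three can be read.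

Compound 4 `CCC1=C(OC)C(CC)(CC)C(=O)C(C(=O)/C=C/c2ccc(CC)cc2)=C1O` is not yet measured. It differs from compound 3 by methyl in place of hydrogen on a saturated chain carbon bound to an aromatic carbon, the same change that leads from compound 1 to compound 2, at the same place. Since that change gave no change at the digits printed from compound 1 to compound 2 (within the scatter) on the core of compound 1, the step for compound 4 is expected to be no change at the digits printed from compound 3 to compound 4 (within the scatter). Compound 4 is thus estimated at 1 ug/mL in this assay, with an expected range from 0.5 ug/mL to 2.2 ug/mL.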

Compound 4, concentration for half-maximal effect: 2.6 ug/mL
Beside the measured number, compound 4's estimate is 2.6-fold (0.41 log units) below it, outside the stated range (above it).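

In this assay, going from 4-methylphenyl to 4-ethylphenyl gives a 2.6-fold higher number from compound 3 to compound 4 (0.41 log units; beyond the scatter) on one core, while the same change on the core of compound 1 gives no change at the digits printed from compound 1 to compound 2 (within the scatter) and so leaves the printed value unmoved. Although only the first of these steps lies beyond the scatter, the two steps themselves cannot be told apart, so the data give no firm sign that the core alters the outcome of this change: the same change on two cores in this assay, no change at the digits printed (within the scatter) from compound 1 to compound 2 and a 2.6-fold higher number (0.41 log units; beyond the scatter) from compound 3 to compound 4, 2.6-fold (0.41 log units) apart, within the scatter of two such steps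

This does not show that the change carries over unaltered from one core to the other, and with a single pair on each core it establishes no rule for the series.

The compounds shown leave open how a longer chain such as propyl, a branched isopropyl group, or a carboxylic acid in place of the ethyl group would read on either core. They also leave open which part of the difference between the core of compound 1 and the core of compound 3 matters for this assay.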